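Trimming the Sulfonyl Chain: From Compound 3 to Compound 4

This account rests on a few compounds, and the source may have more. Where it says the series, first, only, none or still open, it means among the compounds named here.

Compound 1 `Cc1ccccc1S(=O)(=O)NC(=O)c1ccc(Nc2nc(NC3(c4ccc(Cl)cc4)CC3)nc(OCC(F)(F)F)n2)cc1` — 100%
Compound 2 `CC(C)(C)NC(=O)NCCS(=O)(=O)NC(=O)c1ccc(Nc2nc(NC3(c4ccc(Cl)cc4)CC3)nc(OCC(F)(F)F)n2)cc1` — 96%
Compound 3 `CC(C)(C)OC(=O)NCCS(=O)(=O)NC(=O)c1ccc(Nc2nc(NC3(c4ccc(Cl)cc4)CC3)nc(OCC(F)(F)F)n2)cc1` — 92%

All three share one core and differ only in the group on the sulfonyl sulfur. In an ADME assay on microsomes from liver (Homo sapiens) for metabolic stability, with a stated time of 10 min (a higher number here means that more of the compound is left, a lower number that less of the compound is left), compound 1 gives 100%, compound 2 gives 96% and compound 3 gives 92%. The number for compound 3 is the smallest of the three, yet the steps to it are a number 8 percentage points lower from compound 1 to compound 3 (within the scatter) and a number 4 percentage points lower from compound 2 to compound 3 (within the scatter), so the three compounds cannot be told apart on this read-out.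

Compound 4 `CCS(=O)(=O)NC(=O)c1ccc(Nc2nc(NC3(c4ccc(Cl)cc4)CC3)nc(OCC(F)(F)F)n2)cc1` has not yet been measured. The change from compound 3 is hydrogen in place of (tert-butoxycarbonyl)amino on a saturated chain carbon, two bonds along the chain from a sulfonyl sulfur. It removes the whole end of the chain, leaving a plain ethyl on the sulfonyl sulfur.

The steps measured so far all concern this same sulfonyl substituent. Swapping the 2-methylphenyl for a long carbamoyl- or carbamate-bearing chain gave a number 4 percentage points lower from compound 1 to compound 2 (within the scatter) and a number 8 percentage points lower from compound 1 to compound 3 (within the scatter), and exchanging tert-butoxy for (tert-butyl)amino gave a number 4 percentage points lower from compound 2 to compound 3 (within the scatter). None of these moved the number beyond the scatter, so no step beyond the scatter is expected for compound 4 either. Compound 4 is expected to give 92%, in a range from 80% to 100%. That expected step is no change at the digits printed from compound 3 to compound 4 (within the scatter).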

Compound 4, percent of the compound remaining: 100%
Beside the measured number, compound 4's estimate is 8 percentage points below it; the measured number falls inside the stated range.
By their numbers in this assay, from the lowest: compounds 3, 2, 1 and 4 (each within the scatter of the next).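

Cutting the chain back to a plain ethyl takes away the whole (tert-butoxycarbonyl)amino end, with its 8 heavy atoms, yet this assay shows a number 8 percentage points higher from compound 3 to compound 4 (within the scatter), and taking away the ((tert-butyl)carbamoyl)amino end gives a number 4 percentage points higher from compound 2 to compound 4 (within the scatter), so neither end is needed for the number to stay inside the scatter. Putting ethyl in place of 2-methylphenyl on the sulfonyl sulfur gives no change at the digits printed from compound 1 to compound 4 (within the scatter), which means that a small plain chain, a substituted phenyl and two long chains bearing a carbonyl group can no longer be told apart on this read-out, and the position tolerates all four groups shown here. Nothing available gives a reason for this flat result.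

From the compounds shown here alone, whether any group on the sulfonyl sulfur can move this number beyond the scatter remains open, and a free amine or a carboxylic acid on the saturated chain carbon, two bonds along the chain from a sulfonyl sulfur, or a longer plain chain such as butyl, would test that. All four compounds also share one core, so how much the rest of the molecule contributes to the number cannot be judged from them.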